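Compound 3 and the step to compound 4

The source may hold more compounds than are shown below. What is called first, only, known or untested is meant among the compounds shown, and "the series" means these compounds.

Measured in an ADME assay on microsomes from liver (Rattus norvegicus) for metabolic stability; a higher number here means that the compound lasts longer, a lower number that the compound disappears faster:
- Compound 1 `CC(C)C(Cc1ncc[nH]1)c1ccc(-c2ccc3cccc(F)c3c2)[nH]c1=O`: < 0.0667 h, which is a limit of the assay and not a number
- Compound 2 `CC(C)C(Cc1nnc[nH]1)c1ccc(-c2ccc3cccc(F)c3c2)[nH]c1=O`: 0.1 h
- Compound 3 `CC(C)C(Cc1nnn[nH]1)c1ccc(-c2ccc3cccc(F)c3c2)[nH]c1=O`: 2.08 h

Compound 3 stands highest of the three in this assay at 2.08 h. Its nearest measured neighbour is compound 2, and a 21-fold higher number from compound 2 to compound 3 (1.32 log units; beyond the scatter) is a large step, beyond the scatter.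

Compound 4 `CC(C)C(c1ccc(-c2ccc3cccc(F)c3c2)[nH]c1=O)N1CCNC1=O` loses the tetrazole-bearing side group of compound 3 and gains a non-aromatic ring: 2-oxoimidazolidin-1-yl in place of (1H-tetrazol-5-yl)methyl on a saturated chain carbon bound to an aromatic carbon and a saturated chain carbon.

The closest evidence comes from the ring exchanges on the chain. Both an at least 31-fold higher number from compound 1 to compound 3 (1.49 log units; beyond the scatter) and a 21-fold higher number from compound 2 to compound 3 (1.32 log units; beyond the scatter) are large, whereas the floor of an at least 1.4-fold higher number from compound 1 to compound 2 (0.17 log units; that floor lies within the scatter) lies within the scatter. Among the measured compounds shown here, no measured step covers the exchange for a non-aromatic ring, so the size of the change remains uncertain. Given the size of a 21-fold higher number from compound 2 to compound 3 (1.32 log units; beyond the scatter), a clear fall is expected once the 1H-tetrazol-5-yl ring has gone. The expected change is a 6.9-fold lower number from compound 3 to compound 4 (0.84 log units; beyond the scatter). Compound 4 is estimated at 0.3 h, within an expected range of 0.08 h to 1.2 h.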

Compound 4, half-life: 0.283 h
Beside the measured number, compound 4's estimate is 1.1-fold (0.03 log units) above it; low and high end bracket the measured number.
By their numbers in this assay, from the lowest: compound 2; then compound 4; then compound 3. At a limit, below all of these: compound 1.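

In this assay, the step of a 7.3-fold lower number from compound 3 to compound 4 (0.87 log units; beyond the scatter) shows that losing (1H-tetrazol-5-yl)methyl at this saturated chain carbon costs a clear part of the number, yet the step of a 2.8-fold higher number from compound 2 to compound 4 (0.45 log units; beyond the scatter) shows that a non-aromatic ring can still stand above an aromatic one here. Among the four compounds, then, 2-oxoimidazolidin-1-yl falls between the rings already compared, and compound 3 alone keeps the highest number. Against compound 1, whose value is a limit of the assay and not a number, only a floor can be read: an at least 4.2-fold higher number from compound 1 to compound 4 (0.62 log units; beyond the scatter).

The compounds shown leave open whether the change from compound 3 to compound 4 comes from the ring itself or from the loss of the methyl link, as both differ at once. They also leave open how an open-chain urea or a carboxylic acid would behave at this place.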